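The compounds below may be only part of what the source reports. "The series", "measured", "known", "first", "only" and "open" are said of these compounds alone.

In a functional assay on K562 cells (Homo sapiens) for inhibition, read by sulforhodamine B assay, with a stated time of 48 h (on this read-out higher numbers stand for weaker inhibition of growth and lower numbers for stronger inhibition of growth), compound 2 `CC1=CC[C@H](C(C)(C)NC(=S)N/N=C/c2ccccc2)CC1` gives 6300 nM. Compound 1 `CC1=CC[C@H](C(C)(C)NC(=S)NN)CC1` reaches only the limit > 100000 nM, which is not a number. Compound 3 `CC1=CC[C@H](C(C)(C)NC(=S)N/N=C/c2ccc(F)cc2)CC1` likewise stops at the limit > 100000 nM, so only a bound is known for it. Two of the three values sit at the limit of > 100000 nM in this assay, at which 2 of the 3 values shown sit. Among the compounds with values here, the single measured step that touches compound 3, an at least 15-fold higher number from compound 2 to compound 3 (1.20 log units; beyond the scatter), came from fluoro in place of hydrogen on an aromatic carbon. Compound 4 `CC1=CC[C@H](C(C)(C)NC(=S)N/N=C/c2ccco2)CC1` differs from compound 3 by furan-2-yl in place of 4-fluorophenyl on a carbon with a double bond to nitrogen. Within the data shown here, no measured step involves a furan, so the direction is uncertain. The expectation for compound 4 is 40000 nM, between 5000 nM and 100000 nM. The step of an at least 2.5-fold lower number from compound 3 to compound 4 (0.39 log units; beyond the scatter) is thus expected only loosely, with a fair chance that compound 4 again stops at the limit.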

Compound 4, concentration for 50% growth inhibition: 100 nM
Compound 4: middle estimate off by 400-fold (2.60 log units), on the high side; measured number outside the range, below it.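

In this assay, the group on the carbon with a double bond to nitrogen proves able to shift growth inhibition strongly in the favourable direction: furan-2-yl in place of phenyl gives a 63-fold lower number from compound 2 to compound 4 (1.80 log units; beyond the scatter). The same furan-2-yl gives an at least 1000-fold lower number from compound 3 to compound 4 (3.00 log units; beyond the scatter) against 4-fluorophenyl, and an at least 1000-fold lower number from compound 1 to compound 4 (3.00 log units; beyond the scatter) against the unsubstituted nitrogen end. These last two sizes are only bounds, because compound 1 and compound 3 each stop at a limit: the limit of > 100000 nM in this assay, at which 2 of the 4 values shown sit.

From the compounds shown here alone, how thiophen-2-yl or pyridin-2-yl would fare on this carbon remains open. So does whether a methyl group on the furan ring would keep the effect.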